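Swapping the enone direction on a trimethoxyphenyl core

This account rests on a few compounds, and the source may have more. Where it says the series, first, only, none or still open, it means among the compounds named here.

Compound 1, `COc1cc(-c2cc(C(=O)/C=C/c3ccc(Cl)cc3)nc3cc(-c4ccccc4)nn23)cc(OC)c1OC`, gives 21600 nM in a functional assay on MDA-MB-231 cells (Homo sapiens) for antiproliferative activity, read by MTT assay, with a stated time of 24 h; a lower number here means a stronger inhibitor, a higher number a weaker inhibitor.
Compound 2, `COc1cc(-c2cc(/C=C/C(=O)c3ccc(Cl)cc3)nc3cc(-c4ccccc4)nn23)cc(OC)c1OC`, gives 32500 nM.
Compound 3, `COc1cc(-c2cc(/C=C/C(=O)c3ccccc3)nc3cc(-c4ccccc4)nn23)cc(OC)c1OC`, gives 15800 nM.

Among these three, compound 3 has the lowest number in this assay: a 2.1-fold lower number from compound 2 to compound 3 (0.31 log units; beyond the scatter) is a modest step beyond the scatter, whereas a 1.4-fold lower number from compound 1 to compound 3 (0.14 log units; within the scatter) stays within it. The next compound is compound 4, `COc1cc(-c2cc(C(=O)/C=C/c3ccccc3)nc3cc(-c4ccccc4)nn23)cc(OC)c1OC`. It differs from compound 3 by a change in how the same atoms are joined: (2-phenylethenyl)carbonyl in place of 2-benzoylethenyl on an aromatic carbon. This swap has been made once before among the measured pair, where a 1.5-fold higher number from compound 1 to compound 2 (0.18 log units; within the scatter) was seen, a change that stays within the scatter. Compound 4 carries the arrangement of compound 1, so the step is expected to run the other way, toward a somewhat lower number, yet still within the scatter. Compound 4 is thus expected to show a 1.4-fold lower number from compound 3 to compound 4 (0.16 log units; within the scatter). The estimate for compound 4 in this assay is 11000 nM, with a range from 5000 nM to 25000 nM.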

Compound 4, half-maximal inhibitory concentration: 19200 nM
Beside the measured number, compound 4's estimate is 1.7-fold (0.24 log units) below it, and the stated range covers the measured number.
By their numbers in this assay, from the lowest: compounds 3, 4, 1 and 2 (each within the scatter of the next, the first and the last beyond it).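

In this assay, reversing the enone without the chloro also stays within the scatter (a 1.2-fold higher number from compound 3 to compound 4 (0.08 log units; within the scatter)), so at this position the enone direction has now made no step beyond the scatter, with or without the chloro. Reversing the enone and removing the chloro together, two changes at once, also stays within it (a 1.7-fold lower number from compound 2 to compound 4 (0.23 log units; within the scatter)). Hydrogen in place of chloro with the enone of compound 1 gives a step within the scatter as well (a 1.1-fold lower number from compound 1 to compound 4 (0.05 log units; within the scatter)), and its size can be set against the same change with the reversed enone: the same change on two cores in this assay, a 2.1-fold lower number (0.31 log units; beyond the scatter) from compound 2 to compound 3 and a 1.1-fold lower number (0.05 log units; within the scatter) from compound 1 to compound 4, 1.8-fold (0.26 log units) apart, within the scatter of two such steps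

The compounds shown leave open whether an amine or a carboxylic acid in place of the chloro would give a step beyond the scatter. They also leave open how a saturated chain in place of the enone would read in this assay.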